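Clearance notes: replacing ethylsulfonyl on the ring nitrogen

This account rests on a few compounds, and the source may have more. Where it says the series, first, only, none or still open, it means among the compounds named here.

In an ADME assay on the whole organism (Rattus norvegicus, strain Wister-Han) for pharmacokinetics, read by LC-MS, at a dose of 1 mg/kg by the intravenous route (on this read-out higher numbers stand for fast clearance and lower numbers for slow clearance), compound 2 (`CCS(=O)(=O)N1CC(Oc2cncc(N3C(=O)c4ccc(Cl)cc4C3(C)C)c2)C1`) gives 3.8 mL/min/kg. Compound 1 (`CC1(C)c2cc(Cl)ccc2C(=O)N1c1cncc(OC2CN(C(=O)c3ncccc3Cl)C2)c1`) gives 3.1 mL/min/kg. For the measured compounds named here, these two values lie within the scatter of each other, so compound 2 holds no distinct place on the numbers so far.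

The next structure is compound 3 (`Cn1cc(C(=O)N2CC(Oc3cncc(N4C(=O)c5ccc(Cl)cc5C4(C)C)c3)C2)cn1`), with (1-methyl-1H-pyrazol-4-yl)carbonyl in place of ethylsulfonyl on an amine nitrogen in a ring. Going by the values given here, only one measured step bears on this place, ethylsulfonyl in place of (3-chloropyridin-2-yl)carbonyl. Because a 1.2-fold higher number from compound 1 to compound 2 (0.09 log units; within the scatter) stays within the scatter, no step beyond the scatter is expected in this assay, and no direction is favoured. Among the compounds with values here, this is a thin basis: no measured compound carries the entering group, so the range is kept wide, more so towards faster clearance. The estimated change is a 1.1-fold higher number from compound 2 to compound 3 (0.02 log units; within the scatter).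

For compound 3 the expected value is 4 mL/min/kg, with an estimated range of 2 mL/min/kg to 9 mL/min/kg.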

Compound 3, clearance: 3.8 mL/min/kg
Estimate against measurement, compound 3: 1.1-fold (0.02 log units) above; low and high end bracket the measured number.
By their numbers in this assay, from the lowest: compounds 1, 2 and 3 (each within the scatter of the next).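

On the amine nitrogen in the four-membered ring, a carbonyl group carrying a five-membered aromatic ring with 2 hetero atoms can stand in place of ethylsulfonyl in this assay with no step beyond the scatter: no change at the digits printed from compound 2 to compound 3 (within the scatter). The two carbonyl-linked aromatic groups are likewise not separated, with 1-methyl-1H-pyrazol-4-yl in place of 3-chloropyridin-2-yl on the carbonyl carbon giving a 1.2-fold higher number from compound 1 to compound 3 (0.09 log units; within the scatter), so all three groups now shown at this place lie within the scatter of one another, a statement limited to compounds 1, 2 and 3. No measurement is available that bears on why these groups are not told apart on this read-out.

Still open, on these data alone, is whether a plain alkyl chain on the ring nitrogen, or an entering group carrying a free amine or a carboxylic acid, would give a step beyond the scatter at this place. Also open is whether the same holds once the shared core is changed, as the three compounds shown differ only in the group on this nitrogen.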